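A 1H-tetrazol-5-yl swap on compound 2

This account rests on a few compounds, and the source may have more. Where it says the series, first, only, none or still open, it means among the compounds named here.

In a physicochemical assay for solubility, in phosphate buffer, measured as thermodynamic solubility, at pH 7.4 (on this read-out lower numbers stand for lower solubility and higher numbers for higher solubility), compound 1 `CS(=O)(=O)NC(=O)CCc1cn(-c2ccc(F)cc2)nc1-c1ccc(Cl)cc1` gives 25000 nM as a measured number. Compound 2 `CS(=O)(=O)NCCCc1cn(-c2ccc(Br)cc2)nc1-c1ccc(Cl)cc1` gives < 5000 nM in this assay and that value is a limit. Compound 3 `Clc1ccc(-c2nn(-c3ccc(Br)cc3)cc2CCc2nnn[nH]2)cc1` carries 1H-tetrazol-5-yl in place of (methanesulfonamido)methyl on a saturated chain carbon, two bonds along the chain from an aromatic carbon. Going by the values given here, no measured pair shows this change, so the expectation leans on compound 1 with 25000 nM as the only number available. An upward move is expected, estimated as an at least 4.0-fold higher number from compound 2 to compound 3 (0.60 log units; beyond the scatter) in this assay and thus beyond the scatter. Compound 3 is estimated at 20000 nM (range 5000 nM to 80000 nM).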

Compound 3, solubility: 150000 nM
For compound 3 the middle estimate is 7.5-fold (0.88 log units) below the measured one, outside the stated range (above it).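

On the saturated chain carbon, two bonds along the chain from an aromatic carbon, 1H-tetrazol-5-yl in place of (methanesulfonamido)methyl gives an at least 30-fold higher number from compound 2 to compound 3 (1.47 log units; beyond the scatter) in this assay, the first change in a single place among these compounds. The full size of this step stays unknown because compound 2 is read only as a limit: the limit of < 5000 nM in this assay, at which 1 of the 3 values shown sits.

Going by these compounds, whether a carboxylic acid or an amine on the same chain would reach a similar number stays open. So does whether a longer chain ending in 1H-tetrazol-5-yl would keep the rise.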